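The compounds below may be only part of what the source reports. "The series", "measured", "known", "first", "only" and "open" are said of these compounds alone.

Working notes on the series. Compound 1 (`CCCC(=O)OCSc1ccccc1C(=O)NCCC(N)=O`), compound 2 (`CCCC(=O)OCSc1ccccc1C(=O)Nc1cccc(C(N)=O)c1`) and the unmeasured compound 3 (`CCCC(=O)OCSc1ccccc1C(=O)N[C@@H]1CCC[C@H]1C(N)=O`) are compared here. In an ADME assay on CEM-SS cells (Homo sapiens) for cytotoxicity, read by XTT assay, with a stated time of 6 days (on this read-out lower numbers stand for higher toxicity in this test and higher numbers for lower toxicity in this test), compound 1 gives > 100 uM, which is a limit of the assay and not a number. The position of compound 1 is therefore only bounded: the limit of > 100 uM in this assay, at which 1 of the 2 values shown sits. In this assay compound 2 gives a true number, 17.5 uM.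

Compound 3 departs from compound 1 by one change: 2-carbamoylcyclopentyl in place of 2-carbamoylethyl on an amide-type nitrogen. In words, 2-carbamoylcyclopentyl stands in place of 2-carbamoylethyl on an amide-type nitrogen. Among the compounds with values here, no measured step shows this change, so the expectation is tentative. The measured number of compound 2, 17.5 uM, gives the only reference point inside the range of this assay. A value for compound 3 is expected to fall between that reference point and the limit of compound 1, or to reach that limit again. The estimated move is modest and towards higher toxicity: an at least 1.4-fold lower number from compound 1 to compound 3 (0.15 log units; that floor lies within the scatter). For compound 3 the expected value is 70 uM, with an estimated range of 25 uM to 150 uM.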

Compound 3, half-maximal toxic concentration: 43.7 uM
Beside the measured number, compound 3's estimate is 1.6-fold (0.20 log units) above it; measured number inside the range.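

In this assay the change of 2-carbamoylethyl to 2-carbamoylcyclopentyl on an amide-type nitrogen gives an at least 2.2-fold lower number from compound 1 to compound 3 (0.35 log units; beyond the scatter). This step lies beyond the scatter, so this place on the shared core responds to the change, which keeps the carbamoyl group and brings in a five-membered non-aromatic ring of carbon only, with 2 defined stereocentres. The size of the step remains a lower bound, since compound 1 stands at a limit of the assay and not at a number: the limit of > 100 uM in this assay, at which 1 of the 3 values shown sits.

The compounds shown leave open whether the lower number follows from the ring itself or from the added carbons alone, a question that a longer open chain ending in the same carbamoyl group could settle, and whether the opposite configuration at the two stereocentres would read the same. Also open, on these data alone, is how a carboxylic acid or an amine in place of the carbamoyl group on the cyclopentyl ring would read in this assay, and how far the true value of compound 1 lies from its limit.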